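Moving the pyridine nitrogen on the amine-borne substituent

This account rests on a few compounds, and the source may have more. Where it says the series, first, only, none or still open, it means among the compounds named here.

Three compounds have been measured in an assay on isolated protein for activation of cGMP-dependent protein kinase 1 (Homo sapiens), read by ADP-Glo, with stated times of 120 min and 40 min; on this read-out higher numbers stand for an effect only at larger amounts of compound and lower numbers for an effect already at smaller amounts:
compound 1 `Cn1cc(CN2CCC[C@H](OCc3cc(Cl)cc(Cl)c3)[C@@H]2c2ccccc2)cn1`, which gives 110000 nM;
compound 2 `Clc1cc(Cl)cc(CO[C@H]2CCCN(Cc3nccs3)[C@H]2c2ccccc2)c1`, for which this assay returns only a limit, > 200000 nM;
compound 3 `Clc1cc(Cl)cc(CO[C@H]2CCCN(Cc3cccnc3)[C@H]2c2ccccc2)c1`, which gives 112000 nM.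

Compound 3 holds the higher of the two actual numbers, but its nearest neighbour is compound 1, and that difference, a 1.0-fold higher number from compound 1 to compound 3 (0.01 log units; within the scatter), is within the scatter. The third value is a limit, (the limit of > 200000 nM in this assay, at which 1 of the 3 values shown sits), so compound 2 cannot be placed against compound 3 more closely than an at least 1.7-fold lower number from compound 2 to compound 3 (0.25 log units; that floor lies within the scatter).

Compound 4 `Clc1cc(Cl)cc(CO[C@H]2CCCN(Cc3ccncc3)[C@H]2c2ccccc2)c1` differs from compound 3 only in the substituent on the saturated chain carbon bound to the amine nitrogen in the ring: pyridin-4-yl in place of pyridin-3-yl on a saturated chain carbon bound to an amine nitrogen in a ring. The measured steps at this very position are all exchanges of one small aromatic ring for another. They read a 1.0-fold higher number from compound 1 to compound 3 (0.01 log units; within the scatter), an at least 1.8-fold higher number from compound 1 to compound 2 (0.25 log units; that floor lies within the scatter) and an at least 1.7-fold lower number from compound 2 to compound 3 (0.25 log units; that floor lies within the scatter), and none of them moves beyond the scatter. Nothing among these numbers singles out the shift of the ring nitrogen as a change of consequence, so no step beyond the scatter is expected here in this assay.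

Compound 4 is therefore estimated at 115000 nM, with a range from 50000 nM to 250000 nM. This estimate amounts to an expected 1.0-fold higher number from compound 3 to compound 4 (0.01 log units; within the scatter).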

Compound 4, half-maximal effective concentration: > 200000 nM
Compound 4: a limit, no number; the forecaster's own chance of this, stated with the estimate: 30%; at least 1.7-fold (0.24 log units) between middle value and limit.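

In this assay compound 4 gives > 200000 nM, which is a limit and not a number, and it now shares that limit with compound 2: the limit of > 200000 nM in this assay, at which 2 of the 4 values shown sit.

Shifting the ring nitrogen, with pyridin-4-yl in place of pyridin-3-yl, gives an at least 1.7-fold higher number from compound 3 to compound 4 (0.25 log units; that floor lies within the scatter), while pyridin-4-yl in place of 1-methyl-1H-pyrazol-4-yl gives an at least 1.8-fold higher number from compound 1 to compound 4 (0.25 log units; that floor lies within the scatter); both floors lie within the scatter, so neither step is shown to be a real change, and its full size stays unknown. What the result adds is that two substituents with the same atoms, joined differently, here do not both return a number, whereas the step between compound 2 and compound 4 cannot be read, both values being limits.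

From the compounds shown here alone, whether compound 4 truly parts from compound 3 remains open, for compound 4 has no number that would settle it. Also open is how this position responds to pyridin-2-yl, or to a non-aromatic group such as a dimethylamino group or a carboxylic acid on the saturated chain carbon, since every compound shown carries a small aromatic ring there.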